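A few compounds are considered here, and "the series" means these few. Any claim that something is new, unique, unknown or untested is made for them only; others in the source may bear on it.

- Compound 1 `Cc1ccc(-c2cc(-c3ccoc3)cc(-c3ccc(Cl)s3)n2)o1`: 12700 nM
- Compound 2 `Cc1cccc(-c2cc(-c3ccoc3)cc(-c3ccc(Cl)s3)n2)c1`: 13700 nM
- Compound 3 `Cc1ccc(-c2cc(-c3ccoc3)cc(-c3ccc(Cl)s3)n2)cc1`: 17900 nM

In a functional assay on K562 cells (Homo sapiens) for cytotoxicity, read by ELISA, with a stated time of 4 days (on this read-out higher numbers stand for weaker inhibition and lower numbers for stronger inhibition), compound 3 cannot be separated from the other two compounds: the measurements show a 1.4-fold higher number from compound 1 to compound 3 (0.15 log units; within the scatter) and a 1.3-fold higher number from compound 2 to compound 3 (0.12 log units; within the scatter). Compound 4 `Clc1ccc(-c2cc(-c3ccoc3)cc(-c3ccccc3Cl)n2)s1` carries one change, 2-chlorophenyl in place of 4-methylphenyl next to the ring nitrogen: 2-chlorophenyl in place of 4-methylphenyl on an aromatic carbon. The nearest guides are the earlier swaps of this same group, which gave a 1.1-fold higher number from compound 1 to compound 2 (0.03 log units; within the scatter) alongside the two steps above. For the measured compounds named here, none of the measured compounds has a chlorine on this group, so this evidence is indirect. No step beyond the scatter is therefore expected, and the estimate is a 1.3-fold lower number from compound 3 to compound 4 (0.11 log units; within the scatter). For compound 4 the expected value is 14000 nM, with an estimated range of 6000 nM to 32000 nM.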

Compound 4, half-maximal inhibitory concentration: 15800 nM
Compound 4: middle estimate off by 1.1-fold (0.05 log units), on the low side; the measured number falls inside the stated range.
By their numbers in this assay, from the lowest: compounds 1, 2, 4 and 3 (each within the scatter of the next).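

For the compounds shown here, the 2-chlorophenyl group, the first here to carry a chlorine at this place next to the ring nitrogen, gives no step that can be told from the scatter in this assay (a 1.1-fold lower number from compound 3 to compound 4 (0.05 log units; within the scatter); a 1.2-fold higher number from compound 2 to compound 4 (0.06 log units; within the scatter); a 1.2-fold higher number from compound 1 to compound 4 (0.09 log units; within the scatter)). Across compounds 1 to 4, then, swapping a methyl-bearing ring for a chlorine-bearing one leaves the number unchanged within the scatter. Nothing measured here explains this flat result.
Still open, as far as these compounds go, is whether an amine or a carboxylic acid on this ring would move the number. The compounds shown also leave open what changing the furan-3-yl or 5-chlorothiophen-2-yl group would do.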